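A few compounds are considered here, and "the series" means these few. Any claim that something is new, unique, unknown or untested is made for them only; others in the source may bear on it.

Compound 3 `Cn1c(N2N=C(c3ccccc3)CC2c2ccc(F)cc2)nc(-c2ccc(Cl)cc2)c(C#N)c1=O` is the weakest-looking member of a small set tested in a functional assay on A549 cells (Homo sapiens) for antiproliferative activity, with a stated time of 72 h (a lower number here means a stronger inhibitor, a higher number a weaker inhibitor), where compound 3 gives 27800 nM. Its nearest neighbour is compound 2 `COc1ccc(C2CC(c3ccccc3)=NN2c2nc(-c3ccc(Cl)cc3)c(C#N)c(=O)n2C)cc1`, which in this assay gives 23800 nM; the single-site step a 1.2-fold higher number from compound 2 to compound 3 (0.07 log units; within the scatter) lies within the scatter. Far below both sits compound 1 `Cc1ccc(C2=NN(c3nc(-c4ccccc4)c(C#N)c(=O)n3C)C(c3ccc(F)cc3)C2)cc1`, which in this assay gives 2000 nM.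

Compound 4 `Cc1ccc(C2=NN(c3nc(-c4ccc(Cl)cc4)c(C#N)c(=O)n3C)C(c3ccc(F)cc3)C2)cc1` differs from compound 3 by methyl in place of hydrogen on an aromatic carbon, sitting on the six-membered carbon ring para to a large group. For the measured compounds named here, no measured pair in this set traces a methyl-for-hydrogen change, so there is no step that bears directly on it. Going by the values given here, the one measured step, from compound 2 to compound 3, concerns a different substituent and is within the scatter, offering no direction. Compound 1, which carries the methyl on this ring but lacks the chloro on the other aryl, gives a much lower number, yet two changes separate it from compound 4, so its value cannot be read as a guide.

The expectation for the step from compound 3 to compound 4 is therefore a small one, a 1.5-fold lower number from compound 3 to compound 4 (0.19 log units; within the scatter), likely within the scatter. Compound 4 is estimated at 18000 nM, with a range from 6000 nM to 45000 nM.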

Compound 4, half-maximal inhibitory concentration: 35600 nM
Compound 4: middle estimate off by 2.0-fold (0.30 log units), on the low side; the range from low to high includes it.
By their numbers in this assay, from the lowest: compound 1; then compounds 2, 3 and 4 (each within the scatter of the next).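

For the compounds shown here, on the phenyl to 4-methylphenyl change, para to a large group, the step of a 1.3-fold higher number from compound 3 to compound 4 (0.11 log units; within the scatter) in this assay gives the first direct reading of this position: with the chloro present on the other aryl, methyl in place of hydrogen leaves the number within the scatter. The large step is instead the one that adds the chloro to the other aryl, an 18-fold higher number from compound 1 to compound 4 (1.25 log units; beyond the scatter), which shows that with the 4-methylphenyl group held fixed, this single change separates the two compounds by far more than the scatter, so the low number of compound 1 does not come with the methyl alone. No measurement shown here gives a reason for the size of either step.

The compounds shown leave open whether the methyl step would also stay within the scatter on a partner of compound 1 without the chloro, so the two changes have been read together on only one side. They also leave open whether an amine, a carboxylic acid or a longer chain on this ring, or a bromo in place of the chloro, would change the number in this series.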